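This account rests on a few compounds, and the source may have more. Where it says the series, first, only, none or still open, it means among the compounds named here.

In a functional assay on HT cells (Homo sapiens) for antiproliferative activity, read by fluorescence, with a stated time of 72 h (a higher number here means a weaker inhibitor of growth, a lower number a stronger inhibitor of growth), three compounds that differ only in the group on sulfur have been measured. Compound 1 `CC(C)c1n[nH]c2c(NCc3ccc(-c4ccccn4)cc3)nc(SCCN)nc12`, with 2-aminoethyl, gives 22 nM. Compound 2 `CC(C)c1n[nH]c2c(NCc3ccc(-c4ccccn4)cc3)nc(SC3CCCCC3O)nc12`, with 2-hydroxycyclohexyl, gives 636 nM. Compound 3 `CC(C)c1n[nH]c2c(NCc3ccc(-c4ccccn4)cc3)nc(SC[C@H](O)CN)nc12`, with 3-amino-2-hydroxypropyl, gives 63 nM, the middle of the three numbers.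

Compound 4 `C=CCSc1nc(NCc2ccc(-c3ccccn3)cc2)c2[nH]nc(C(C)C)c2n1` is still unmeasured. It differs from compound 3 as follows: vinyl in place of 2-amino-1-hydroxyethyl on a saturated chain carbon bound to a sulfur. In words, vinyl takes the place of 2-amino-1-hydroxyethyl on a saturated chain carbon bound to a sulfur.

For the measured compounds named here, three measured steps bear on this. The two compounds with an amino group lie close together, at a 2.9-fold higher number from compound 1 to compound 3 (0.46 log units; beyond the scatter). The one without it stands well apart, at a 29-fold higher number from compound 1 to compound 2 (1.46 log units; beyond the scatter) and a 10-fold lower number from compound 2 to compound 3 (1.00 log units; beyond the scatter). Compound 4 also lacks an amino group, though three compounds make a thin basis for any pattern. A modest rise is therefore expected in this assay, with the estimated step being a 4.0-fold higher number from compound 3 to compound 4 (0.60 log units; beyond the scatter). Compound 4 is estimated at 250 nM, with an expected range from 90 nM to 700 nM.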

Compound 4, concentration for 50% growth inhibition: 1010 nM
Compound 4: the middle estimate sits 4.0-fold (0.61 log units) below what was measured; the whole stated range lies below it.
By their numbers in this assay, from the lowest: compound 1; then compound 3; then compounds 2 and 4 (each within the scatter of the next).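

In this assay, putting allyl in place of 3-amino-2-hydroxypropyl gives a 16-fold higher number from compound 3 to compound 4 (1.20 log units; beyond the scatter), and putting it in place of 2-aminoethyl gives a 46-fold higher number from compound 1 to compound 4 (1.66 log units; beyond the scatter), so a plain allyl chain on sulfur does not stand in for either amino-bearing chain. Allyl and 2-hydroxycyclohexyl cannot be told apart, at a 1.6-fold higher number from compound 2 to compound 4 (0.20 log units; within the scatter), so among these four compounds the two with an amino group, compound 1 and compound 3, give the two lowest numbers, and no compound goes against this. Nothing measured here explains why these groups differ.

Allyl lacks both the amino group and the hydroxyl of 3-amino-2-hydroxypropyl, so the share of each remains unseparated, and a 3-aminopropyl or a 2-hydroxyethyl chain would carry only one of them. Also open, going by these compounds, is how a dimethylamino group or a carboxylic acid at the chain end would compare with the simple amino group.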